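Hydroxy to Chloro on the Shared Core

The source may report more compounds than this note shows. Statements on the series, on what has been measured and on what is new or still open speak of the compounds shown alone.

Compound 1, `COc1ccc(C(=O)/C=C/c2cc3ccccc3[nH]c2=O)cc1`, gives 2120 nM in a functional assay on NCI-H522 cells (Homo sapiens) for cytotoxicity, read by sulforhodamine B assay, with a stated time of 24 h; a lower number here means a stronger inhibitor of growth, a higher number a weaker inhibitor of growth.
Compound 2, `O=C(/C=C/c1cc2ccccc2[nH]c1=O)c1ccc(O)cc1`, gives 1700 nM in this assay.

Compound 2 holds the lower of the two numbers, but the step of a 1.2-fold lower number from compound 1 to compound 2 (0.10 log units; within the scatter) is within the scatter, so the two compounds cannot be separated. Compound 3, `O=C(/C=C/c1cc2ccccc2[nH]c1=O)c1ccc(Cl)cc1`, differs from compound 2 by chloro in place of hydroxy on an aromatic carbon. Among the compounds with values here, only that one measured step touches this position, and no measured step exchanges hydroxy for chloro, so there is no basis for expecting a change beyond the scatter. The expected step is a 1.1-fold lower number from compound 2 to compound 3 (0.05 log units; within the scatter). Compound 3 is estimated at 1500 nM, with a range from 500 nM to 5000 nM.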

Compound 3, concentration for 50% growth inhibition: 2230 nM
Compound 3: the middle estimate sits 1.5-fold (0.17 log units) below what was measured; measured number inside the range.
By their numbers in this assay, from the lowest: compounds 2, 1 and 3 (each within the scatter of the next).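

Chloro, with no hydrogen-bond donor or acceptor, stays within the scatter of both earlier groups: the comparison gives a 1.3-fold higher number from compound 2 to compound 3 (0.12 log units; within the scatter) against hydroxy and a 1.1-fold higher number from compound 1 to compound 3 (0.02 log units; within the scatter) against methoxy. Hydroxy, methoxy and chloro on this aromatic carbon therefore cannot be separated in this assay, even though hydroxy brings a hydrogen-bond donor and chloro does not. No measurement available here explains this result.

On these data alone, whether an amine, a carboxylic acid or a longer chain such as butoxy at this position would give a number beyond the scatter remains open.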